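The compounds below may be only part of what the source reports. "The series", "measured", "known", "first", "only" and "open" are said of these compounds alone.

In an ADME assay on CEM-SS cells (Homo sapiens) for cytotoxicity, read by XTT assay, with a stated time of 6 days (on this read-out lower numbers stand for higher toxicity in this test and higher numbers for lower toxicity in this test), three compounds sharing one core have been measured: compound 1 `CCCC(=O)OCSc1ccccc1C(=O)NCCCCCC(N)=O` gives 16.3 uM, compound 2 `CCCC(=O)OCSc1ccccc1C(=O)NCCCNC(C)=O` gives 21.1 uM, and compound 3 `CCCC(=O)OCSc1ccccc1C(=O)NCCCCCCNC(C)=O` gives 8 uM, the lowest of the three. Compound 4 `CCCC(=O)OCSc1ccccc1C(=O)NCC(=O)N(C)C` has not yet been measured. Its change from compound 3 is dimethylcarbamoyl in place of 5-acetamidopentyl on a saturated chain carbon bound to an amide-type nitrogen. The closest evidence is a 2.6-fold lower number from compound 2 to compound 3 (0.42 log units; beyond the scatter), a modest step to the longer chain, alongside a 2.0-fold lower number from compound 1 to compound 3 (0.31 log units; beyond the scatter), also modest, while a 1.3-fold higher number from compound 1 to compound 2 (0.11 log units; within the scatter) stays within the scatter. Among the measured compounds shown here, no measured compound carries dimethylcarbamoyl. Losing the long chain should therefore reverse those modest steps, and the expected step is a 2.5-fold higher number from compound 3 to compound 4 (0.40 log units; beyond the scatter). For compound 4 the estimated value is 20 uM, with an expected range of 9 uM to 45 uM.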

Compound 4, half-maximal toxic concentration: 38.3 uM
The estimate for compound 4 lay 1.9-fold (0.28 log units) below the measured number; low and high end bracket the measured number.
By their numbers in this assay, from the lowest: compound 3; then compounds 1, 2 and 4 (each within the scatter of the next, the first and the last beyond it).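

In this assay dimethylcarbamoyl in place of 5-acetamidopentyl on this saturated chain carbon raises the number clearly (a 4.8-fold higher number from compound 3 to compound 4 (0.68 log units; beyond the scatter)). In place of 4-carbamoylbutyl it does so too (a 2.3-fold higher number from compound 1 to compound 4 (0.37 log units; beyond the scatter)). In place of 2-acetamidoethyl the difference stays within the scatter (a 1.8-fold higher number from compound 2 to compound 4 (0.26 log units; within the scatter)), so a short group with 0 hydrogen-bond donors and the 2-acetamidoethyl chain cannot be told apart here.

No measurement shown explains these steps. From the compounds shown here alone, how an amine or a carboxylic acid at this place would read remains open.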